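The source may hold more compounds than are shown below. What is called first, only, known or untested is meant among the compounds shown, and "the series" means these compounds.

In a functional assay on HEK293 cells (Homo sapiens) for cytotoxicity (a higher number here means that more compound is tolerated, a lower number that less compound is tolerated), compound 3 `COc1ccc([C@H]2CC(=O)N(c3cccc(N(C)C)c3)C2)cc1OC1CCCC1` gives > 10000 nM, which is a limit and not a number. Compound 1 `COc1ccc([C@H]2CC(=O)N(Cc3cccc([N+](=O)[O-])c3)C2)cc1OC1CCCC1` gives > 10000 nM, also a limit. Compound 2 `COc1ccc([C@H]2CC(=O)N(c3cccc(O)c3)C2)cc1OC1CCCC1` gives > 10000 nM, again a limit. The picture so far is the limit of > 10000 nM in this assay, at which 3 of the 3 values shown sit. Compound 4 `COc1ccc([C@H]2CC(=O)N(c3cc(N)cc(N)c3)C2)cc1OC1CCCC1` carries 3,5-diaminophenyl in place of 3-(dimethylamino)phenyl on an amide-type nitrogen in a ring. The closest measured changes at this nitrogen are a step that the two limits leave unreadable from compound 1 to compound 2 and a step that the two limits leave unreadable from compound 1 to compound 3, and the change on the aromatic carbon is a step that the two limits leave unreadable from compound 2 to compound 3. None of these gives a size, so no shift in a known direction can be carried over. The estimate is therefore a step that the limit leaves unreadable from compound 3 to compound 4, with no change beyond the scatter expected. For compound 4 the estimated value is 12000 nM, within an expected range of 4000 nM to 30000 nM.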

Compound 4, half-maximal cytotoxic concentration: > 10000 nM
Compound 4 ended at the assay's limit (the forecaster's own chance of this, stated with the estimate: 80%); the middle value is on the limit's open side.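

In this assay compound 4 gives > 10000 nM, which is a limit and not a number. Going by these compounds alone, no step linking it to compound 1, compound 2 or compound 3 can be read. The compounds shown leave open whether any change on the amide-type nitrogen shifts the tolerated concentration: the limit of > 10000 nM in this assay, at which 4 of the 4 values shown sit.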